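Benzylidene cyclohexanones: a phenol for a chlorine

The compounds below may be only part of what the source reports. "The series", "measured", "known", "first", "only" and "open" are said of these compounds alone.

Measured compounds:
- compound 1 `O=C1/C(=C/c2ccccc2)CCC/C1=C\c1ccc(Cl)cc1`: "not determined" (no result reported) in an assay on isolated protein for inhibition of Alpha glucosidase (Homo sapiens), with stated times of 5 min and 15 min; on this read-out lower numbers stand for stronger inhibition and higher numbers for weaker inhibition
- compound 2 `O=C(C1=C(O)/C(=C/c2ccc(O)c(O)c2)CCC1)c1ccccc1`: 41000 nM
- compound 3 `O=C(/C=C(O)/C=C/c1cc(O)ccc1O)c1cc(O)ccc1O`: 19600 nM

Compound 1 stands at "not determined" (no result reported) in this assay, so nothing measured places it against compound 2 or compound 3. Those two carry different cores from compound 1, and their values in this assay show only weak inhibition, compound 2 giving 41000 nM and compound 3 giving 19600 nM, so the series as measured has not yet produced a potent member.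

Compound 4 `O=C1/C(=C/c2ccccc2)CCC/C1=C\c1cccc(O)c1` keeps the core of compound 1 and changes one substituent: 3-hydroxyphenyl in place of 4-chlorophenyl on a double-bonded chain carbon bound to a double-bonded ring carbon. Within the data shown here, both measured compounds carry hydroxyl groups on their aromatic rings, as compound 4 does, yet neither shares the core of compound 1, so no measured pair tells how large this step should be. Among the measured compounds shown here, with no reference step, the expectation is none beyond the scatter of this assay; if anything the hydroxyl bearing compound 4 is guessed to land where compound 2 and compound 3 land.

Compound 4 is thus expected to give about 30000 nM in this assay, within a range from 8000 nM to 120000 nM.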

Compound 4, half-maximal inhibitory concentration: 28400 nM
Compound 4: middle estimate off by 1.1-fold (0.02 log units), on the high side; the range from low to high includes it.
By their numbers in this assay, from the lowest: compounds 3, 4 and 2 (each within the scatter of the next, the first and the last beyond it).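

In this assay compound 1 stands at "not determined" (no result reported) and compound 4 gives 28400 nM so no step can be read between them. No supporting evidence bears on this result. The compounds shown leave open how 3-hydroxyphenyl in place of 4-chlorophenyl changes inhibition on the shared core.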